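A Methyl Added on Two Different Urea Cores

The source may report more compounds than this note shows. Statements on the series, on what has been measured and on what is new or still open speak of the compounds shown alone.

Compound 1 `O=C(Nc1ccc(OCCCN2CCCCC2)cc1)Nc1cc(Cl)cc(Cl)c1` is the anchor of this small set. In an assay on CHO cells for displacement of a labelled ligand from histamine receptor H3 (Macaca mulatta), read by scintillation counting, with a stated time of 1 h (a lower number here means a stronger inhibitor, a higher number a weaker inhibitor), compound 1 gives 3.4 nM. Compound 2 `Cc1c(Cl)cc(NC(=O)Nc2ccc(OCCCN3CCCCC3)cc2)cc1Cl` differs from it by methyl in place of hydrogen on an aromatic carbon, and in this assay compound 2 gives 18.2 nM. That change produced a 5.4-fold higher number from compound 1 to compound 2 (0.73 log units; beyond the scatter).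

Compound 3 `CC(=O)N1CCN(C(=O)Nc2ccc(N3CCC(N4CCCC4C)C3)cc2)CC1` is built on another core; the difference between the two cores is not broken down here. In this assay compound 3 gives 34.1 nM. Its number lies within the scatter of compound 2, while it is beyond the scatter above compound 1, so compound 3 is the weaker binder of those two.

Compound 4 `CC(=O)N1CCN(C(=O)Nc2ccc(N3CCC(N4CCCC4C)C3)c(C)c2)CC1` carries the same kind of change relative to compound 3, namely (methyl in place of hydrogen on an aromatic carbon). The surroundings are not identical: in compound 2 the methyl sits ortho to two chloro groups and para to a large group, whereas in compound 4 it sits ortho to a large group and meta to a large group. For the measured compounds named here, only one measured instance of this kind of change exists, and it weakened binding. Compound 4 is therefore expected to bind less strongly than compound 3, by an estimated 2.6-fold higher number from compound 3 to compound 4 (0.42 log units; beyond the scatter), a judgement that rests on a 5.4-fold higher number from compound 1 to compound 2 (0.73 log units; beyond the scatter) tempered by the different placement. The estimate for compound 4 in this assay is 90 nM, with a range from 30 nM to 270 nM.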

Compound 4, inhibition constant: 23 nM
For compound 4 the middle estimate is 3.9-fold (0.59 log units) above the measured one, and the stated range ends above it.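

In this assay, methyl in place of hydrogen on an aromatic carbon, ortho to a large group and meta to a large group, gave a 1.5-fold lower number from compound 3 to compound 4 (0.17 log units; within the scatter), so on this core the change did not separate the two compounds. Set beside the earlier instance, the same change did not carry a single size of step from one core to the other, and a weakening seen on one core could not be assumed on the second: the same change on two cores in this assay, a 5.4-fold higher number (0.73 log units; beyond the scatter) from compound 1 to compound 2 and a 1.5-fold lower number (0.17 log units; within the scatter) from compound 3 to compound 4, 7.9-fold (0.90 log units) apart, beyond the scatter of two such steps. This does not show what sets the two steps apart, since the methyl stands in a different place in each pair, so core and placement differ together, and two pairs give no rule for the series as a whole.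

The compounds shown leave open whether a methyl ortho to a large group and meta to a large group on the core of compound 1 would behave as it does on the core of compound 3. They also leave open whether another group at the aromatic carbon that carries the methyl in compound 4, such as a fluoro, a methoxy or an ethyl group, would give a step beyond the scatter.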